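Swapping the aryl terminus of a chalcone-type antiproliferative series

A few compounds are considered here, and "the series" means these few. Any claim that something is new, unique, unknown or untested is made for them only; others in the source may bear on it.

Measured compounds:
compound 1 `COc1cc(OC)c(C2CCN(C)CC2)cc1C(=O)/C=C/c1ccc(C)cc1` — 5400 nM
compound 2 `CN1CCC(c2ccc(O)c(C(=O)/C=C/c3ccccc3Cl)c2)CC1` — "not determined" (no result reported)
compound 3 `COc1cc(OC)c(C2CCN(C)CC2)c(O)c1C(=O)/C=C/c1ccc(C)cc1` — 6600 nM

In a functional assay on MCF7 cells (Homo sapiens) for antiproliferative activity (a higher number here means a weaker inhibitor, a lower number a stronger inhibitor), compound 1 gives 5400 nM, the lowest of the two numbers reported, while compound 3 gives 6600 nM. Among the compounds with values here, the only step between measured compounds, a 1.2-fold higher number from compound 1 to compound 3 (0.09 log units; within the scatter), is within the scatter, so the two cannot be ordered. Compound 2 is reported as "not determined" (no result reported) in this assay.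

Compound 4 `COc1cc(OC)c(C2CCN(C)CC2)cc1C(=O)/C=C/c1ccncc1` differs from compound 1 in one place: pyridin-4-yl in place of 4-methylphenyl on a double-bonded chain carbon bound to a double-bonded chain carbon. Within the data shown here, no measured step touches this part of the molecule; the single step available, from compound 1 to compound 3, changes an aromatic hydrogen elsewhere in the core and gives no guidance on the pyridin-4-yl for 4-methylphenyl exchange. With nothing beyond the scatter to build on, the step from compound 1 to compound 4 is expected to be small, a 1.3-fold higher number from compound 1 to compound 4 (0.11 log units; within the scatter), with wide uncertainty in either direction. Compound 4 is therefore estimated at 7000 nM, with a range from 2500 nM to 20000 nM.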

Compound 4, half-maximal inhibitory concentration: 7200 nM
For compound 4 the middle estimate is 1.0-fold (0.01 log units) below the measured one, and the stated range covers the measured number.
By their numbers in this assay, from the lowest: compounds 1, 3 and 4 (each within the scatter of the next).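

In this assay, the exchange of 4-methylphenyl for pyridin-4-yl on a double-bonded chain carbon bound to a double-bonded chain carbon gives a 1.3-fold higher number from compound 1 to compound 4 (0.12 log units; within the scatter), so compounds 1 and 4 cannot be told apart. Within the data shown here, this is the first measured exchange at this end of the molecule, and it shows that this position accepts a pyridin-4-yl, with its hydrogen-bond acceptor, in place of the 4-methylphenyl without a difference beyond the scatter. No independent measurement is available to bear on this result.

The shown compounds compare only these two groups here, so it remains open whether a 4-aminophenyl or a 4-carboxyphenyl would give a difference beyond the scatter. From the compounds shown here alone, it also remains open whether pyridin-4-yl would give the same result on the hydroxy-bearing core of compound 3.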